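The source may report more compounds than this note shows. Statements on the series, on what has been measured and on what is new or still open speak of the compounds shown alone.

In a functional assay on Jurkat cells (Homo sapiens) (a lower number here means a stronger inhibitor, a higher number a weaker inhibitor), compound 1 `CC(C)[C@H](NC(=O)COc1cccc2ccccc12)C(=O)N[C@@H](CC(=O)O)C(=O)COc1ccc(C#N)cc1` gives > 100000 nM, which is a limit of the assay and not a number. For the measured compounds named here, compound 2 `CC(C)[C@H](NC(=O)COc1cccc2ccccc12)C(=O)N[C@@H](CC(=O)O)C(=O)COc1cc(F)cc(F)c1F` gives 30000 nM, the only exact number so far. Going by the values given here, the single measured step, an at least 3.3-fold lower number from compound 1 to compound 2 (0.52 log units; beyond the scatter), replaced 4-cyanophenyl with 2,3,5-trifluorophenyl, and one end of it rests on (the limit of > 100000 nM in this assay, at which 1 of the 2 values shown sits). Compound 3 `CC(C)[C@H](NC(=O)COc1cccc2ccccc12)C(=O)N[C@@H](CC(=O)O)C(=O)COc1c(F)cc(F)cc1F` has 2,4,6-trifluorophenyl in place of 2,3,5-trifluorophenyl on an oxygen on a saturated carbon. That step involved a different swap, so it is only a loose guide to the size of this change. The expected change is a 2.0-fold lower number from compound 2 to compound 3 (0.30 log units; within the scatter), with its direction uncertain. For compound 3 the estimated value is 15000 nM, within a range of 2500 nM to 70000 nM.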

Compound 3, half-maximal inhibitory concentration: 6840 nM
The estimate for compound 3 lay 2.2-fold (0.34 log units) above the measured number; the range from low to high includes it.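

In this assay, the same atoms arranged differently on the ring change the result: 2,4,6-trifluorophenyl in place of 2,3,5-trifluorophenyl gives a 4.4-fold lower number from compound 2 to compound 3 (0.64 log units; beyond the scatter). Replacing 4-cyanophenyl with 2,4,6-trifluorophenyl gives an at least 14-fold lower number from compound 1 to compound 3 (1.16 log units; beyond the scatter). Compound 1 stands at a limit of the assay, so that step has no known upper end: the limit of > 100000 nM in this assay, at which 1 of the 3 values shown sits.

The compounds shown leave open how a plain phenyl or a pentafluorophenyl would compare on this oxygen. It therefore remains unclear how much depends on having fluorines at all, rather than on their arrangement.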